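The source may report more compounds than this note shows. Statements on the series, on what has been measured and on what is new or still open speak of the compounds shown alone.

Three compounds have been measured in a functional assay on HCT-116 cells (Homo sapiens) for antiproliferative activity, read by CCK-8 assay, with a stated time of 72 h, tested at 8 uM; on this read-out lower numbers stand for a weaker effect and higher numbers for a stronger effect at the one concentration tested:

- compound 1 `CCCCn1cnc2c(Nc3cccc(Cl)c3)nc(NCOCc3ccc(/C=C/C(=O)Nc4ccccc4N)cc3)nc21` gives 10.9%
- compound 2 `CC(C)n1cnc2c(Nc3ccccc3)nc(NCOCc3ccc(/C=C/C(=O)Nc4ccccc4N)cc3)nc21` gives 41.7%
- compound 3 `CC1CCN(c2nc(Cl)nc3c2ncn3Cc2ccc(/C=C/C(=O)Nc3ccccc3N)cc2)CC1` gives 26.9%

Among these three numbers, compound 3 stands second highest. Its nearest neighbour is compound 2, whose number lies higher by more than the scatter, and its furthest is compound 1, whose number lies lower by more than the scatter.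

Compound 4 `Nc1ccccc1NC(=O)/C=C/c1ccc(Cn2cnc3c(Nc4cccc(Cl)c4)nc(Cl)nc32)cc1` differs from compound 3 in a single place: (3-chlorophenyl)amino in place of 4-methylpiperidin-1-yl on an aromatic carbon. Among the compounds with values here, no pair of measured compounds shows this same change, so its effect in this assay cannot be read from a measured step. Compound 1 also carries a (3-chlorophenyl)amino group and gives the lowest of the three numbers, while compound 2 carries the closely related phenylamino group and gives the highest; both also differ from compound 4 elsewhere, so they point in no single direction. The step of a number 0.1 percentage points higher from compound 3 to compound 4 (within the scatter) is therefore expected to stay within the scatter, with no clear direction. For compound 4 the expected value in this assay is 27%, with a range from 10% to 45%.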

Compound 4, a percentage reported as inhibition, at one concentration (the size of the read-out at that concentration, not a potency): 15.8%
Beside the measured number, compound 4's estimate is 11.2 percentage points above it; measured number inside the range.
By their numbers in this assay, from the lowest: compounds 1 and 4 (each within the scatter of the next); then compound 3; then compound 2.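

In this assay, placing (3-chlorophenyl)amino on this aromatic carbon in place of 4-methylpiperidin-1-yl gives a number 11.1 percentage points lower from compound 3 to compound 4 (beyond the scatter), so this position does respond to the group it carries, at least with the chloro group and the rest of compound 3 held fixed. The change replaces a non-aromatic ring with an aromatic ring of carbon only and adds a hydrogen-bond donor, and this one step cannot separate those differences. No available evidence explains the step.

It remains open how a morpholin-4-yl or dimethylamino group at this carbon would compare with the two groups shown, which could help separate the effect of ring type from that of the donor. It is also unknown whether this step would hold on a core carrying a different group in place of the chloro group.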